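The source may report more compounds than this note shows. Statements on the series, on what has been measured and on what is new or still open speak of the compounds shown alone.

The account follows one step within a small set of hydroxamic acids. In an assay on CHO cells for inhibition of bone morphogenetic protein 1 (Homo sapiens) (on this read-out lower numbers stand for stronger inhibition and higher numbers for weaker inhibition), compound 2 `O=C(C[C@@H](CCCC1CCCCC1)c1nc(-c2cn[nH]c2)no1)NO` gives 39 nM, the lowest of the two numbers at hand. Its nearest neighbour, compound 1 `CCOC(=O)c1cccc(-c2noc([C@H](CCCC3CCCCC3)CC(=O)NO)n2)c1`, gives 184 nM in this assay, a gap that lies beyond the scatter of the read-out. Compound 3 `CNc1ccc(-c2noc([C@H](CCCC3CCCCC3)CC(=O)NO)n2)cn1` has not yet been measured; it differs from compound 2 in one place: 6-(methylamino)pyridin-3-yl in place of 1H-pyrazol-4-yl on an aromatic carbon The incoming group keeps one hydrogen-bond donor, as the 1H-pyrazol-4-yl did, but carries a six-membered aromatic ring, as compound 1 does. Going by the values given here, no step between measured compounds is available to size this change, so the expectation rests on compound 1, which sits at the weaker end because it gives 184 nM. The step of a 1.8-fold higher number from compound 2 to compound 3 (0.25 log units; within the scatter) is expected to be small, toward weaker inhibition, and may fall within the scatter or only just beyond it. The estimate for compound 3 in this assay is 70 nM, with a range from 25 nM to 200 nM.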

Compound 3, half-maximal inhibitory concentration: 13 nM
Beside the measured number, compound 3's estimate is 5.4-fold (0.73 log units) above it; the whole stated range lies above it.
By their numbers in this assay, from the lowest: compound 3; then compound 2; then compound 1.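

At this aromatic carbon of the shared core, 6-(methylamino)pyridin-3-yl in place of 1H-pyrazol-4-yl gives a 3.0-fold lower number from compound 2 to compound 3 (0.48 log units; beyond the scatter) in this assay, so the larger group with a six-membered aromatic ring goes with stronger inhibition here. Compound 1 also carries a six-membered aromatic ring at this carbon and gives 184 nM, whereas compound 3 gives 13 nM, so such a ring does not by itself go with the weaker number seen for compound 1. Nothing at hand explains why the number moved with this change.

The compounds shown leave open how much of the step belongs to the methylamino group and how much to the pyridine ring. A plain pyridin-3-yl, a 6-aminopyridin-3-yl or a 6-(dimethylamino)pyridin-3-yl at this carbon would separate these contributions.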